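Thiophene Ketone to Tolyl Ketone in a Chalcone Amide Series

The compounds below may be only part of what the source reports. "The series", "measured", "known", "first", "only" and "open" are said of these compounds alone.

Measured compounds:
compound 1 `COC(=O)c1cc(-c2cccc(NC(=O)c3ccc(/C=C/C(=O)c4cccs4)cc3)c2)on1`: "not determined" (no result reported)
compound 2 `CCCOc1ccc(C(=O)/C=C/c2ccc(C(=O)Nc3cccc(-c4cc(C(=O)OC)no4)c3)cc2)cc1`: > 40 ug/mL

Two compounds of a shared core have been taken into an ADME assay on Vero cells (Chlorocebus sabaeus) for cytotoxicity, read by MTT assay, with a stated time of 72 h; on this read-out lower numbers stand for higher toxicity in this test and higher numbers for lower toxicity in this test. For compound 1 no result was reported in this assay, so its entry reads "not determined" (no result reported). Compound 2 in this assay gave > 40 ug/mL, which is a limit of the test rather than a number. This is the only figure shown, and it is the limit of > 40 ug/mL in this assay, at which 1 of the 2 values shown sits. Among the compounds with values here, compound 1 therefore stands without a number of its own, and the one further value in the set is this limit.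

The unmeasured compound 3, `COC(=O)c1cc(-c2cccc(NC(=O)c3ccc(/C=C/C(=O)c4ccc(C)cc4)cc3)c2)on1`, differs from compound 1 in a single place: 4-methylphenyl in place of thiophen-2-yl on a carbonyl carbon. Within the data shown here, no pair of measured compounds that differ in one place exists here, so no measured step can be called on. In this assay the change is expected to move the read-out by no more than the usual scatter, with no direction favoured. Compound 3 is expected to give an estimated value of about 40 ug/mL in this assay, in a range from 15 ug/mL to 80 ug/mL, with a fair chance that only a limit is reported.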

Compound 3, half-maximal cytotoxic concentration: > 80 ug/mL
Compound 3: no number, only a limit (the forecaster's own chance of this, stated with the estimate: 60%); middle value at least 2.0-fold (0.30 log units) from the limit.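

Within the data shown here, compound 2 and compound 3 each carry only a limit in this assay, and the step between them cannot be read, so this result yields no new step. The compounds shown leave open how large the half-maximal cytotoxic concentration of either compound is, and whether 4-methylphenyl in place of thiophen-2-yl shifts it at all.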